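Two Methyls on the Aryl Ring and Microsomal Half-Life

The source may hold more compounds than are shown below. What is called first, only, known or untested is meant among the compounds shown, and "the series" means these compounds.

Compound 1, `Cc1cc(C)c(-c2nc(CN3CCC(C(=O)NCCCN4C[C@H](C)C[C@H](C)C4)CC3)c(C)o2)c(C)c1`, in an ADME assay on microsomes from liver (Rattus norvegicus) for metabolic stability, read by LC-MS, using NADPH, at 37 degrees C (a lower number here means that the compound disappears faster, a higher number that the compound lasts longer), gives a limit of > 0.5 h.
Compound 2, `Cc1ccc(-c2nc(CN3CCC(C(=O)NCCCN4C[C@H](C)C[C@H](C)C4)CC3)c(C)o2)cc1`, in this assay gives a limit of > 0.5 h.

Both measured values are limits of the assay rather than numbers: each compound was still present when the measurement window closed. Compound 2 therefore stands at the same limit as compound 1, and the step that the two limits leave unreadable from compound 1 to compound 2 cannot be read in either direction.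

Compound 3, `Cc1cc(C)cc(-c2nc(CN3CCC(C(=O)NCCCN4C[C@H](C)C[C@H](C)C4)CC3)c(C)o2)c1`, differs from compound 2 by 3,5-dimethylphenyl in place of 4-methylphenyl on an aromatic carbon. Going by the values given here, the one measured step also rearranged the methyl groups on this same aryl ring, yet it gives no readable size due to the limit of > 0.5 h in this assay, at which 2 of the 2 values shown sit. Among the compounds with values here, no measured step therefore bears on the new change with a readable size, and nothing in the data points to a shift beyond the usual scatter.

The expected step that the limit leaves unreadable from compound 2 to compound 3 is accordingly estimated to be none beyond the scatter. For compound 3 the estimated half-life is 0.8 h, with an expected range from 0.35 h to 2.5 h, and most likely the assay again reports only a limit.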

Compound 3, half-life: < 0.5 h
Compound 3: no number, only a limit; the forecaster's own chance of this, stated with the estimate: 70%; at least 1.6-fold (0.20 log units) between middle value and limit.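

In this assay compound 3 gives < 0.5 h, which is a limit of the assay and not a number. With 3,5-dimethylphenyl on this aromatic carbon, the aryl change now has a direction, though no readable size: the result is a number no higher from compound 2 to compound 3 (the limit leaves the size open), and the comparison with the 2,4,6-trimethylphenyl compound gives a number no higher from compound 1 to compound 3 (the limit leaves the size open). The split also does not follow the number of methyl groups in the group names, since compound 1 (2,4,6-trimethylphenyl) and compound 2 (4-methylphenyl) stand on one side of the same cut-off and compound 3 (3,5-dimethylphenyl) stands on the other.

On these data alone, because all three results are limits, how far apart the three half-lives lie stays open, and the compounds could be close to the cut-off or far from it. Also open, as far as these compounds go, is where an aryl group with a different substituent, such as 4-fluorophenyl or 4-methoxyphenyl, on the same aromatic carbon would fall relative to this cut-off.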